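Dimethylamino in Place of Ethoxy: the Expected Step

A few compounds are considered here, and "the series" means these few. Any claim that something is new, unique, unknown or untested is made for them only; others in the source may bear on it.

Of the compounds shown here, three have so far been measured in an assay on lysate for inhibition of patatin-like phospholipase domain-containing protein 2 (Mus musculus); a lower number here means a stronger inhibitor, a higher number a weaker inhibitor. Compound 1 `CCOC(=O)c1cccc(-c2ccc(Br)cc2)c1` reaches only the limit of this assay, > 200000 nM. Compound 2 `CCOC(=O)c1cccc(-c2ccc(C(C)=O)cc2)c1` carries an acetyl where compound 1 carries a bromo. In this assay compound 2 gives 200000 nM. The step from compound 1 to compound 2 is a number no higher from compound 1 to compound 2 (the limit leaves the size open), and its size cannot be read because one of its ends is the limit (the limit of > 200000 nM in this assay, at which 1 of the 3 values shown sits). Compound 3 `CCOc1ccc(-c2cccc(NC(=O)N(C)C)c2)cc1` gives 9000 nM in this assay, the lowest of the two numbers shown; the nearest number, that of compound 2, sits higher by a gap beyond the usual scatter.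

Compound 4 `CN(C)C(=O)Nc1cccc(-c2ccc(N(C)C)cc2)c1` differs from compound 3 in one place: dimethylamino in place of ethoxy on an aromatic carbon. For the measured compounds named here, no measured step matches this change. Going by the values given here, the only step known, from compound 1 to compound 2, alters a different group, and its size is not readable, so it gives no guide. The leaving ethoxy and the entering dimethylamino each count three heavy atoms, one hydrogen-bond acceptor and no donor, so the expected step from compound 3 to compound 4 in this assay is no change at the digits printed from compound 3 to compound 4 (within the scatter), within the scatter. Compound 4 is therefore estimated at 9000 nM, with a range from 3000 nM to 30000 nM.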

Compound 4, half-maximal inhibitory concentration: 700 nM
Beside the measured number, compound 4's estimate is 13-fold (1.11 log units) above it; the whole stated range lies above it.
By their numbers in this assay, from the lowest: compound 4; then compound 3; then compound 2.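

Dimethylamino in place of ethoxy on an aromatic carbon, para to a large group, gives a 13-fold lower number from compound 3 to compound 4 (1.11 log units; beyond the scatter) in this assay. For the compounds shown here, this shows that the position is sensitive to the group it carries, which the earlier compounds could not show, as none of them changed this group alone. The leaving and entering groups match in heavy atoms, hydrogen-bond donors and hydrogen-bond acceptors, so those counts do not predict the step, and nothing measured here accounts for its size.

On these data alone, it remains open whether the gain is specific to dimethylamino or would also appear with a smaller group such as an unsubstituted amine, a larger one such as diethylamino, or a ring such as morpholine. As far as these compounds go, it is also open whether the same change would have a similar effect on another core, since compound 1 and compound 2 differ from compound 3 in more than one place and offer no direct comparison.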